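A Dichlorinated Sulfonamide Arm on a Thiazole Inhibitor

The compounds below may be only part of what the source reports. "The series", "measured", "known", "first", "only" and "open" are said of these compounds alone.

Of the compounds shown here, three have been measured in an assay on isolated protein for inhibition of kynurenine 3-monooxygenase (Rattus norvegicus); on this read-out lower numbers stand for stronger inhibition and higher numbers for weaker inhibition. Compound 1 `O=C(O)CCC(=O)c1cccc([N+](=O)[O-])c1` is the smallest of them and gives 5770 nM. Compound 2 `Cc1ccc(S(=O)(=O)Nc2nc(-c3ccc(O)c(C)c3)cs2)cc1` joins a sulfonamide to a larger core and gives 114 nM. Compound 3 `Cc1ccc(S(=O)(=O)Nc2nc(-c3cccc([N+](=O)[O-])c3)cs2)cc1` keeps the shared core of compound 2 but carries a nitro group in place of the hydroxyl and methyl groups. Compound 3 gives 48 nM, the lowest of the three numbers; its gap to compound 2 lies beyond the scatter, as does the far wider gap to compound 1.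

Compound 4 `O=[N+]([O-])c1cccc(-c2csc(NS(=O)(=O)c3ccc(Cl)c(Cl)c3)n2)c1` changes compound 3 at one place only: 3,4-dichlorophenyl in place of 4-methylphenyl on a sulfonyl sulfur. Among the compounds with values here, no measured pair shows this exchange, so the expectation rests on compound 3 alone, which gives 48 nM in this assay. The expected step is a 1.2-fold lower number from compound 3 to compound 4 (0.08 log units; within the scatter), most likely not beyond the scatter in either direction. In this assay compound 4 is therefore estimated at 40 nM, with a plausible range from 12 nM to 130 nM.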

Compound 4, half-maximal inhibitory concentration: 120 nM
Beside the measured number, compound 4's estimate is 3.0-fold (0.48 log units) below it, and the stated range covers the measured number.
By their numbers in this assay, from the lowest: compound 3; then compounds 2 and 4 (each within the scatter of the next); then compound 1.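

Within the data shown here, this is the first comparison that changes only one place, and it shows that the aryl group on a sulfonyl sulfur affects the result. In this assay, putting 3,4-dichlorophenyl in place of 4-methylphenyl gives a 2.5-fold higher number from compound 3 to compound 4 (0.40 log units; beyond the scatter), so inhibition is weaker with the new group. The two groups have the same ring and the same count of hydrogen-bond donors and acceptors, so a swap that leaves these counts unchanged can still shift the number, and nothing available here explains the shift.

Since the two chlorines enter together, the compounds shown cannot say whether either one alone, as in a 4-chlorophenyl group, would give the same step. Also open, as far as these compounds go, are other groups on this ring, such as a methoxy group, an amine or a carboxylic acid, and whether the same exchange would behave alike with the core substituents of compound 2.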